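Replacing the crotonamide group of compound 1 with a chloroacetamide

The source may report more compounds than this note shows. Statements on the series, on what has been measured and on what is new or still open speak of the compounds shown alone.

Measured compounds:
Compound 1 `C/C=C/C(=O)Nc1cccc(Cn2nc(-c3ccc(Oc4ccccc4)cc3)cc2C(=O)O)c1` — 24100 nM
Compound 2 `C/C=C/C(=O)Nc1cccc(Cn2nc(-c3ccc(Oc4ccccc4)cc3)cc2CO)c1` — 5700 nM
Compound 3 `C/C=C/C(=O)Nc1ccc(Cn2nc(-c3ccc(Oc4ccccc4)cc3)cc2CO)cc1` — 54500 nM

All three were tested in a functional assay on Z-138 cells (Homo sapiens) for inhibition, read by luminescence and CellTiter-Glo, with a stated time of 72 h; on this read-out lower numbers stand for stronger inhibition and higher numbers for weaker inhibition. Compound 1 stands second highest of the three numbers. Its nearest neighbour is compound 3, whose value 54500 nM lies beyond the scatter above it; the furthest is compound 2, and the step of a 4.2-fold lower number from compound 1 to compound 2 (0.63 log units; beyond the scatter) is a modest one, brought about by hydroxymethyl in place of carboxy on an aromatic carbon. Compounds 2 and 3 differ only in where the anilide sits on the benzyl ring, and their values show a wide gap.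

Compound 4 `O=C(CCl)Nc1cccc(Cn2nc(-c3ccc(Oc4ccccc4)cc3)cc2C(=O)O)c1` has not yet been measured. It differs from compound 1 by chloromethyl in place of prop-1-en-1-yl on a carbonyl carbon. None of the measured steps touches this amide substituent, so no measured step bears directly on it; the only shown steps concern the acid and the anilide position. Within the data shown here, with no precedent for the change, compound 4 is expected to stay close to compound 1, that is, no step beyond the scatter in this assay, with an estimated step of a 1.2-fold lower number from compound 1 to compound 4 (0.08 log units; within the scatter). The expected value for compound 4 is therefore 20000 nM, in the range 6000 nM to 70000 nM.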

Compound 4, half-maximal inhibitory concentration: 9100 nM
The estimate for compound 4 lay 2.2-fold (0.34 log units) above the measured number, and the stated range covers the measured number.
By their numbers in this assay, from the lowest: compounds 2 and 4 (each within the scatter of the next); then compound 1; then compound 3.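

In this assay the group on the carbonyl carbon is shown to matter, with a 2.6-fold lower number from compound 1 to compound 4 (0.42 log units; beyond the scatter) when chloromethyl stands in place of prop-1-en-1-yl. The earlier steps shown here and values concerned only the carboxy and hydroxymethyl groups and the placing of the anilide, so this is the only measured sign that this amide substituent alone can shift the number. Nothing measured here explains why the number shifts.

The compounds shown pair chloromethyl only with the carboxy group, so it remains open whether the same change would lower the number when hydroxymethyl stands in place of carboxy, as in compound 2. From the compounds shown here alone, it is also open how an ethenyl, a bromomethyl or a plain methyl group on this carbonyl carbon would read in this assay.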